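Hydroxyphenyl for methoxyphenyl at the aza-ring carbon

This account rests on a few compounds, and the source may have more. Where it says the series, first, only, none or still open, it means among the compounds named here.

Of the compounds shown here, three have been measured in an assay on isolated protein for inhibition of DNA topoisomerase 1 (Homo sapiens), with a stated time of 30 min, tested at 100 uM; a higher number here means a stronger effect of the compound at the concentration tested, a lower number a weaker effect. Compound 1 `COc1ccc(-c2cc3ccccc3c(-c3cccc(OC)c3)n2)cc1` gives 43.2%. Compound 2 `COc1ccc(-c2cc3cc(C)ccc3c(-c3cccc(N)c3)n2)c(C)c1` gives 79.7%. Compound 3 `COc1cccc(-c2nc(-c3ccc(OC)c(OC)c3)cc3cc(C)ccc23)c1` gives 2.9%, the lowest of the three numbers; the nearest, compound 1, sits beyond the scatter above it, and compound 2 sits further above again, also beyond the scatter. Within the data shown here, no pair of measured compounds differs in one place only, so the values show no isolated single-change effect; compound 3 and compound 1 share the 3-methoxyphenyl group yet differ elsewhere in several places.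

Compound 4 `COc1ccc(-c2cc3cc(C)ccc3c(-c3ccc(O)cc3)n2)cc1OC` is not yet measured. It differs from compound 3 as follows: 4-hydroxyphenyl in place of 3-methoxyphenyl on an aromatic carbon.

The hydroxyl group in compound 4 brings a hydrogen-bond donor that compound 3 lacks; among the measured compounds the only one carrying a donor is compound 2, with 79.7%, while the two with methoxy groups at the same site are lower. On that basis the step is expected upward, and probably beyond the scatter, with a number 32.1 percentage points higher from compound 3 to compound 4 (beyond the scatter) expected. For compound 4 the expected value in this assay is 35%, within a range from 5% to 70%.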

Compound 4, a percentage reported as inhibition, at one concentration (the size of the read-out at that concentration, not a potency): 0.3%
Compound 4: the middle estimate sits 34.7 percentage points above what was measured; the whole stated range lies above it.
By their numbers in this assay, from the lowest: compounds 4 and 3 (each within the scatter of the next); then compound 1; then compound 2.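

In this assay, among these compounds, 4-hydroxyphenyl in place of 3-methoxyphenyl, on the aromatic carbon next to the ring nitrogen, gives a number 2.6 percentage points lower from compound 3 to compound 4 (within the scatter) in the first pair of the series that differs in one place only. At this position and on this core, the exchange therefore leaves the read-out unmoved within the scatter: a hydrogen-bond donor enters, the methyl of the methoxy group leaves, the oxygen changes its place on the phenyl ring, and the number does not respond. Compound 3 at 2.9% and compound 4 at 0.3% both stay close to zero at the tested concentration, so any further loss at this position would be hard to see here, and nothing at hand bears on why the exchange has so little effect.

This single pair cannot separate the place of the oxygen on the phenyl ring from the change of methoxy to hydroxy, as the two change together. Going by these compounds, whether a carboxylic acid or a longer alkoxy chain on this phenyl ring would lift the number on this core remains open.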